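Aryl Carbamate Variation on a Shared Core

A few compounds are considered here, and "the series" means these few. Any claim that something is new, unique, unknown or untested is made for them only; others in the source may bear on it.

Compound 1 `CC(C)=CCC/C(C)=C/CC1Cc2c(OCc3ccccc3)cc(=O)n(CCCO)c2CC1(C)C`: 46.5%
Compound 2 `COc1ccc(OCCCOc2cc(=O)n(CCCO)c3c2CC(C/C=C(\C)CCC=C(C)C)C(C)(C)C3)cc1`: 20%
Compound 3 `COc1ccc(NC(=O)Oc2cc(=O)n(CCCO)c3c2CC(C/C=C(\C)CCC=C(C)C)C(C)(C)C3)cc1`: 64.1%

In a functional assay on PANC-1 cells (Homo sapiens) for inhibition, read by MTT assay, with a stated time of 24 h, tested at 10 uM (on this read-out lower numbers stand for less inhibition and higher numbers for more inhibition at the one concentration tested (going by the name of the read-out)), compound 3 stands highest of the three numbers: compound 1 is nearest, a number 17.6 percentage points higher from compound 1 to compound 3 (beyond the scatter), and compound 2 furthest, a number 44.1 percentage points higher from compound 2 to compound 3 (beyond the scatter). Compound 4 `CC(C)=CCC/C(C)=C/CC1Cc2c(OC(=O)Nc3ccc(F)cc3F)cc(=O)n(CCCO)c2CC1(C)C` keeps the carbamate of compound 3 and differs only in the ring on its nitrogen: 2,4-difluorophenyl in place of 4-methoxyphenyl on an amide-type nitrogen. The measured steps all concern the group on the aromatic oxygen, so none of them directly tests a change on the amide-type nitrogen; they show only that the (4-methoxyphenyl)carbamoyl compound sits above the ethers. Compound 4 is therefore expected to stay close to compound 3, with a step of a number 4.1 percentage points lower from compound 3 to compound 4 (within the scatter) within the scatter, and its estimated value is 60% with a range of 40% to 78%.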

Compound 4, a percentage reported as inhibition, at one concentration (the size of the read-out at that concentration, not a potency): 33.7%
Beside the measured number, compound 4's estimate is 26.3 percentage points above it, and the stated range ends above it.
By their numbers in this assay, from the lowest: compound 2; then compound 4; then compound 1; then compound 3.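

In this assay the ring on the amide-type nitrogen proves to matter, with a number 30.4 percentage points lower from compound 3 to compound 4 (beyond the scatter) even though the carbamate is kept. With 2,4-difluorophenyl on that nitrogen the carbamate no longer stands above both ethers, with a number 13.7 percentage points higher from compound 2 to compound 4 (beyond the scatter) and a number 12.8 percentage points lower from compound 1 to compound 4 (beyond the scatter) in the same assay. Nothing measured here explains these steps. On these data alone, whether the change follows from losing the methoxy group or from gaining the fluorines stays open, as does how an unsubstituted phenyl or a 4-fluorophenyl ring on that nitrogen would read.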